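Toward compound 3: a benzodioxin in place of the acetylphenyl

The source may report more compounds than this note shows. Statements on the series, on what has been measured and on what is new or still open speak of the compounds shown alone.

Measured so far:
compound 1, `CN(C)c1ccc(C(=O)Nc2cccc(NC(=O)COc3ccc4c(c3)NC(=O)CC4)c2)cc1`: 3140 nM
compound 2, `CC(=O)c1ccc(OCC(=O)Nc2cccc(NC(=O)c3ccc(N(C)C)cc3)c2)cc1F`: 98 nM

Among the measured compounds shown here, in an assay on isolated protein for inhibition of Rho-associated protein kinase 2 (Homo sapiens), read by scintillation counting, radiometric assay and 33P incorporation, with a stated time of 40 min, in the presence of a further agent that is not named here (a higher number here means a weaker inhibitor, a lower number a stronger inhibitor), compound 2 stands lowest of the two numbers; its only neighbour is compound 1, and the step of a 32-fold lower number from compound 1 to compound 2 (1.51 log units; beyond the scatter) lies beyond the scatter. Compound 3, `CN(C)c1ccc(C(=O)Nc2cccc(NC(=O)COc3ccc4c(c3)OCCO4)c2)cc1`, differs from compound 2 in one place: 2,3-dihydro-1,4-benzodioxin-6-yl in place of 4-acetyl-3-fluorophenyl on an oxygen on a saturated carbon. For the measured compounds named here, the single measured step, a 32-fold lower number from compound 1 to compound 2 (1.51 log units; beyond the scatter), bears on this change: there a group holding a six-membered non-aromatic ring with a hetero atom at the same oxygen gave the much higher number, and compound 3 again carries a six-membered non-aromatic ring at that oxygen. A step upward in this assay is therefore expected, most likely large, though the two hetero atoms in the entering ring leave it uncertain how far toward compound 1 it goes. Compound 3 is estimated at 1200 nM, within 300 nM to 4000 nM, the expected step being a 12-fold higher number from compound 2 to compound 3 (1.09 log units; beyond the scatter).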

Compound 3, half-maximal inhibitory concentration: > 10000 nM
Compound 3 ended at the assay's limit; the forecaster's own chance of this, stated with the estimate: 5%; middle value at least 8.3-fold (0.92 log units) away from the limit.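

Compound 3 has no number in this assay, only a limit of the assay: the limit of > 10000 nM in this assay, at which 1 of the 3 values shown sits. Putting 2,3-dihydro-1,4-benzodioxin-6-yl in place of 4-acetyl-3-fluorophenyl gives an at least 100-fold higher number from compound 2 to compound 3 (2.00 log units; beyond the scatter), with the count of heavy atoms unchanged, so that count alone does not decide the outcome at this oxygen. The 2,3-dihydro-1,4-benzodioxin-6-yl group also fares worse than the other group with a six-membered non-aromatic ring, with an at least 3.1-fold higher number from compound 1 to compound 3 (0.50 log units; beyond the scatter), and so neither ring-bearing group comes near the 4-acetyl-3-fluorophenyl group.

The compounds shown leave open whether the acetyl or the fluorine carries the low number of compound 2, for the two appear only together. They also do not tell whether a phenyl bearing a nitrile or a carboxylic acid in place of the acetyl would hold that number.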